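Swapping trifluoromethyl for methyl on two related cores

The compounds below may be only part of what the source reports. "The series", "measured", "known", "first", "only" and "open" are said of these compounds alone.

Of the compounds shown here, three have so far been tested in an assay on isolated protein for inhibition of ubiquitin carboxyl-terminal hydrolase 47 (Homo sapiens); on this read-out lower numbers stand for stronger inhibition and higher numbers for weaker inhibition. Compound 1 `Nc1nc2ccc(C(F)(F)F)cn2c1-c1ccc(O)cc1` reaches only the edge of what the assay can report: in this assay compound 1 gives > 100000 nM, which is a limit and not a number. Compound 2 `Nc1nc2cc(C(F)(F)F)ccn2c1-c1ccc(O)cc1` is built from the same atoms as compound 1, joined differently; the difference between the two cores is not broken down here. In this assay compound 2 gives > 100000 nM, again a limit rather than a number. Compound 3 `Cc1ccc2nc(N)c(-c3ccc(O)cc3)n2c1` differs from compound 1 by methyl in place of trifluoromethyl on an aromatic carbon. In this assay compound 3 gives > 100000 nM, also a limit. The step that the two limits leave unreadable from compound 1 to compound 3 cannot be read, since (the limit of > 100000 nM in this assay, at which 3 of the 3 values shown sit).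

Compound 4 `Cc1ccn2c(-c3ccc(O)cc3)c(N)nc2c1` is not yet measured. It differs from compound 2 by methyl in place of trifluoromethyl on an aromatic carbon. Among the compounds with values here, this is the same kind of change as the one from compound 1 to compound 3, though the place is not identical: in compound 3 the methyl sits two atoms from the ring nitrogen, whereas in compound 4 it sits opposite the ring nitrogen. Within the data shown here, no measured step shows what this kind of change does, because of the limit of > 100000 nM in this assay, at which 3 of the 3 values shown sit. The step that the limit leaves unreadable from compound 2 to compound 4 is therefore expected to be small. Compound 4 is expected to give 150000 nM in this assay, with a likely range from 50000 nM to 500000 nM, and most probably only a limit once more.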

Compound 4, half-maximal inhibitory concentration: > 100000 nM
Compound 4: only a limit was reported; the forecaster's own chance of this, stated with the estimate: 85%; the middle value is on the limit's open side.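

In this assay compound 4 gives > 100000 nM, a limit and not a number. The step from compound 2 to compound 4 cannot be read, because both compounds sit at the same edge of what the assay can report: the limit of > 100000 nM in this assay, at which 4 of the 4 values shown sit. The compounds shown leave open whether methyl in place of trifluoromethyl changes inhibition at all on either core.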